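Hydroxymethyl becomes methoxy: a step from the limit

The source may report more compounds than this note shows. Statements on the series, on what has been measured and on what is new or still open speak of the compounds shown alone.

Measured in an ADME assay on HepG2 2.2.15 cells (Homo sapiens) for cytotoxicity, read by MTT assay, with a stated time of 8 days; on this read-out higher numbers stand for lower toxicity in this test and lower numbers for higher toxicity in this test:
- compound 1 `O=c1c(CO)cc(-c2ccc(F)nc2F)nn1Cc1ccc(Cl)cc1`: > 100000 nM (a limit)
- compound 2 `N#Cc1ccc(Cn2nc(-c3cc(Cl)c(NCCO)nc3F)c3ccccc3c2=O)cc1`: 32100 nM
- compound 3 `Cc1nc(-c2ccc(F)nc2F)cn(Cc2ccc(Cl)cc2)c1=O`: > 100000 nM (a limit)

Compound 1 stands at the limit of > 100000 nM in this assay, at which 2 of the 3 values shown sit. That reading is a limit, not a number. Compound 4 `COc1cc(-c2ccc(F)nc2F)nn(Cc2ccc(Cl)cc2)c1=O` has the same atoms as compound 1, joined differently, with methoxy in place of hydroxymethyl on an aromatic carbon. Going by the values given here, no measured pair shows this swap, so the expectation rests on compound 1, whose > 100000 nM is a limit. No change beyond the usual scatter is expected in this assay, and the estimated a number no higher from compound 1 to compound 4 (the limit leaves the size open) is small. For compound 4 the estimate is 100000 nM, expected to fall between 35000 nM and 120000 nM.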

Compound 4, half-maximal cytotoxic concentration: 92200 nM
Beside the measured number, compound 4's estimate is 1.1-fold (0.04 log units) above it, and the stated range covers the measured number.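

Compound 4, with methoxy in place of hydroxymethyl on an aromatic carbon opposite the ring nitrogen, gives a true number in this assay: 92200 nM. The swap gives an at least 1.0-fold lower number from compound 1 to compound 4 (0.03 log units; that floor lies within the scatter), so this position can lose the hydroxymethyl hydrogen-bond donor without a shift that the data can show to exceed the scatter. Compound 1 still has only a limit, not a number: the limit of > 100000 nM in this assay, at which 2 of the 4 values shown sit.

As far as these compounds go, the true size of the step stays open. So does the reading with an amine, a carboxylic acid or a longer chain at this position.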